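The source may report more compounds than this note shows. Statements on the series, on what has been measured and on what is new or still open speak of the compounds shown alone.

Measured in a functional assay on Bel7402/5-FU cells (Homo sapiens) for antiproliferative activity, read by MTT assay, with a stated time of 72 h; on this read-out lower numbers stand for stronger inhibition and higher numbers for weaker inhibition:

Compound 1 `C=C1C(=O)O[C@H]2[C@H]1CC/C(COC(=O)Cn1cc(F)c(=O)n(Cc3ccccc3)c1=O)=C\CC[C@@]1(C)O[C@@H]21`: 4270 nM
Compound 2 `C=C1C(=O)O[C@H]2[C@H]1CC/C(COC(=O)CCC(=O)N1CCN(C(=O)Cn3cc(F)c(=O)n(Cc4ccccc4)c3=O)CC1)=C\CC[C@@]1(C)O[C@@H]21`: > 20000 nM

The entry for compound 2 is a limit of the assay, not a number. Within the data shown here, compound 1, at 4270 nM, therefore holds the only actual number so far. Compound 3 `C=C1C(=O)O[C@H]2[C@H]1CC/C(COC(=O)Cn1cc(F)c(=O)n(Cc3ccccc3F)c1=O)=C\CC[C@@]1(C)O[C@@H]21` differs from compound 1 in one place: fluoro in place of hydrogen on an aromatic carbon, which turns benzyl into 2-fluorobenzyl. Among the measured compounds shown here, no measured pair shows this change, so the expectation rests on compound 1 and the change alone. The expected 1.1-fold lower number from compound 1 to compound 3 (0.03 log units; within the scatter) in this assay stays within the usual scatter, with no direction favoured. Compound 3 is expected at 4000 nM, with an estimated range of 1500 nM to 10000 nM.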

Compound 3, half-maximal inhibitory concentration: 3830 nM
The estimate for compound 3 lay 1.0-fold (0.02 log units) above the measured number; the range from low to high includes it.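

In this assay, turning benzyl into 2-fluorobenzyl gives a 1.1-fold lower number from compound 1 to compound 3 (0.05 log units; within the scatter). Among these compounds, this is the first reading at this position, on an aromatic carbon ortho to a large group, and it shows that a single fluoro there leaves the value of compound 1 within the scatter. Nothing shown speaks to why this exchange has so little consequence.

From the compounds shown here alone, whether fluoro on another carbon of that ring would read the same remains open. So does whether a methoxy group, an amine or a carboxylic acid at this position would move the number beyond the scatter.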